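The source may report more compounds than this note shows. Statements on the series, on what has been measured and on what is new or still open speak of the compounds shown alone.

Compound 1 `NC(=S)Nc1cccc(OCCCCCCCCNC(=S)Nc2cc(Cl)cc(Cl)c2)c1`: 12000 nM
Compound 2 `NC(=S)Nc1cccc(OCCCCCCCCNC(=S)Nc2ccccc2)c1`: > 50000 nM (a limit)
Compound 3 `CC(C)(C)c1ccc(NC(=S)NCCCCCCCCOc2cccc(NC(N)=S)c2)cc1`: 17000 nM

Three thioureas built on one shared core have been tested in an ADME assay on Huh-7 cells (Homo sapiens) for cytotoxicity; on this read-out higher numbers stand for lower toxicity in this test and lower numbers for higher toxicity in this test. Compound 1 gives 12000 nM. Compound 2 reaches only the limit > 50000 nM, which is a boundary of the test and not a number. Compound 3 gives 17000 nM, a number that sits beside that of compound 1 rather than apart from it: a 1.4-fold higher number from compound 1 to compound 3 (0.15 log units; within the scatter). Going by the values given here, the step of an at least 2.9-fold lower number from compound 2 to compound 3 (0.46 log units; beyond the scatter) is the only one that separates compound 3 clearly from another compound.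

Compound 4 `NC(=S)Nc1cccc(OCCCCCCCCNC(=S)Nc2ccc3c(c2)CCC3)c1` has not yet been measured. It differs from compound 3 by 2,3-dihydro-1H-inden-5-yl in place of 4-(tert-butyl)phenyl on an amide-type nitrogen. Among the compounds with values here, two measured steps concern changes on the same nitrogen. a 1.4-fold higher number from compound 1 to compound 3 (0.15 log units; within the scatter) shows that exchanging one substituted phenyl for another left the number where it was, while an at least 4.1-fold higher number from compound 1 to compound 2 (0.61 log units; beyond the scatter) shows that stripping the substituents away moved it up to the limit. Since compound 4 keeps a substituted aromatic ring, in the manner of compound 3 in the step of a 1.4-fold higher number from compound 1 to compound 3 (0.15 log units; within the scatter), the step of a 1.3-fold higher number from compound 3 to compound 4 (0.11 log units; within the scatter) is expected to stay small. Compound 4 is therefore estimated at 22000 nM, within a range from 9000 nM to 50000 nM.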

Compound 4, half-maximal cytotoxic concentration: 34000 nM
Beside the measured number, compound 4's estimate is 1.5-fold (0.19 log units) below it; low and high end bracket the measured number.
By their numbers in this assay, from the lowest: compounds 1, 3 and 4 (each within the scatter of the next, the first and the last beyond it). At a limit, above all of these: compound 2.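

At the amide-type nitrogen, 2,3-dihydro-1H-inden-5-yl is the one substituted ring shown that separates clearly from the 3,5-dichlorophenyl group, with a modest step: a 2.8-fold higher number from compound 1 to compound 4 (0.45 log units; beyond the scatter). Against 4-(tert-butyl)phenyl there is no such separation, since the step of a 2.0-fold higher number from compound 3 to compound 4 (0.30 log units; within the scatter) stays inside the usual scatter, and compound 3 also lies within the scatter of compound 1. A substituted aromatic ring at this nitrogen therefore does not tie the number to that of compound 1, though the pattern is only a loose chain in which compound 3 cannot be told apart from either neighbour.

Going by these compounds, the step of an at least 1.4-fold lower number from compound 2 to compound 4 (0.16 log units; that floor lies within the scatter) has a floor within the scatter, so it stays open whether the fused carbon ring truly differs from plain phenyl, because compound 2 sits at a limit: the limit of > 50000 nM in this assay, at which 1 of the 4 values shown sits. Also open, on these data alone, is how this nitrogen would respond to a ring carrying an amine or a carboxylic acid, or to a cyclohexyl group in place of the aromatic ring.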